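A few compounds are considered here, and "the series" means these few. Any claim that something is new, unique, unknown or untested is made for them only; others in the source may bear on it.

Measured in an assay on isolated protein for inhibition of complement C1r subcomponent (Homo sapiens); on this read-out lower numbers stand for stronger inhibition and higher numbers for weaker inhibition:
Compound 1 `O=c1oc(Nc2nncs2)nc2ccccc12` gives > 62500 nM, which is a limit of the assay.
Compound 2 `O=c1oc(Nc2nc[nH]n2)nc2ccccc12` gives > 62500 nM, which is a limit of the assay.
Compound 3 `O=c1oc(Nc2nccs2)nc2ccccc12` gives > 62500 nM, which is a limit of the assay.

Compound 3 stands only at a limit in this assay; the same holds for the other two compounds shown, as the limit of > 62500 nM in this assay, at which 3 of the 3 values shown sit, records. The three measured steps, a step that the two limits leave unreadable from compound 1 to compound 2, a step that the two limits leave unreadable from compound 1 to compound 3 and a step that the two limits leave unreadable from compound 2 to compound 3, are accordingly unreadable in size and direction.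

Compound 4 `O=c1oc(NC2CCSC2)nc2ccccc12` differs from compound 3 by thiolan-3-yl in place of 1,3-thiazol-2-yl on a nitrogen on an aromatic ring. Going by the values given here, none of the measured steps exchanges the aromatic five-membered ring on this nitrogen for a non-aromatic one, so nothing among them fixes the size or direction of this step. With every value shown sitting at the limit described in the limit of > 62500 nM in this assay, at which 3 of the 3 values shown sit, the expectation is that compound 4 will again return a limit rather than a number. Compound 4 is therefore estimated at 100000 nM, with a range from 30000 nM to 400000 nM. This corresponds to an expected step that the limit leaves unreadable from compound 3 to compound 4, which cannot be resolved against a limit.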

Compound 4, half-maximal inhibitory concentration: > 62500 nM
Compound 4 ended at the assay's limit; the forecaster's own chance of this, stated with the estimate: 90%; the middle value does not contradict the limit.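

In this assay compound 4 gives > 62500 nM, which is a limit of the assay. Going by these compounds alone, no step between compound 4 and compound 1, compound 2 or compound 3 can be read. The compounds shown leave open whether any group on this nitrogen changes the inhibition at all: the limit of > 62500 nM in this assay, at which 4 of the 4 values shown sit.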